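The source may report more compounds than this note shows. Statements on the series, on what has been measured and on what is new or still open speak of the compounds shown alone.

Compound 1 `O=c1cc(CSC(=S)N2CCCC2)oc2ccccc12` gives 23400 nM in a functional assay on SW480 cells (Homo sapiens) for antiproliferative activity, read by MTT assay, with a stated time of 72 h (on this read-out higher numbers stand for weaker inhibition and lower numbers for stronger inhibition), and compound 2 `O=c1cc(CSC(=S)N2CCCCC2)oc2ccccc12` gives 13700 nM in this assay. The step of a 1.7-fold lower number from compound 1 to compound 2 (0.23 log units; within the scatter) stays within the scatter. Compound 3 `O=c1cc(CSC(=S)N2CCCC2)oc2cc(Cl)ccc12` reaches only the limit of this assay, > 25000 nM, and so sits at the limit of > 25000 nM in this assay, at which 1 of the 3 values shown sits. Compound 4 `O=c1cc(CSC(=S)N2CCOCC2)oc2cc(Cl)ccc12` differs from compound 3 by morpholin-4-yl in place of pyrrolidin-1-yl on a thiocarbonyl carbon. The measured step that bears on this change is the exchange of the amine ring on the same thiocarbonyl carbon, a 1.7-fold lower number from compound 1 to compound 2 (0.23 log units; within the scatter), which did not move beyond the scatter; the step of an at least 1.0-fold higher number from compound 1 to compound 3 (0.02 log units; that floor lies within the scatter) is also within the scatter. Compound 4 is therefore expected to show no shift beyond the scatter, a step that the limit leaves unreadable from compound 3 to compound 4, and is estimated at 30000 nM, between 14000 nM and 65000 nM, most likely again reported as a limit.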

Compound 4, half-maximal inhibitory concentration: > 25000 nM
Compound 4: a limit, no number; the forecaster's own chance of this, stated with the estimate: 65%; the middle value is on the limit's open side.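

Among the compounds shown here, compound 4 gives a limit in this assay, > 25000 nM, and compound 3 also stands at a limit, so no step between them can be read. The compounds shown leave open how morpholin-4-yl and pyrrolidin-1-yl compare on this core.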